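This account rests on a few compounds, and the source may have more. Where it says the series, first, only, none or still open, it means among the compounds named here.

In a functional assay on CCRF-CEM cells (Homo sapiens) for antiproliferative activity, read by trypan blue exclusion, with a stated time of 72 h (on this read-out higher numbers stand for weaker inhibition and lower numbers for stronger inhibition), compound 1 `COc1ccc(C(=O)NC(N)=O)cc1NC(=O)CBr` gives 1880 nM. Compound 2 `NC(=O)NC(=O)c1ccc(O)c(NC(=O)CBr)c1` gives > 20000 nM, which is a limit of the assay and not a number. This value is the limit of > 20000 nM in this assay, at which 1 of the 2 values shown sits.

Compound 3 `NC(=O)NC(=O)c1ccc(O)c(NC(=O)CCl)c1` differs from compound 2 by a single change, chloro in place of bromo on a saturated chain carbon bound to a carbonyl carbon. For the measured compounds named here, the only measured step, an at least 10-fold higher number from compound 1 to compound 2 (1.02 log units; beyond the scatter), was large, but it came from hydrogen in place of methyl on an oxygen on an aromatic ring. Going by the values given here, it therefore gives no size for the halogen swap, and no measured step covers that swap. No step beyond the scatter is expected in this assay, and compound 3 may well be reported only as a limit too. The expected change is a step that the limit leaves unreadable from compound 2 to compound 3. For compound 3 the estimated value is 22000 nM, with an expected range from 9000 nM to 50000 nM.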

Compound 3, half-maximal inhibitory concentration: > 20000 nM
Compound 3: no number, only a limit; the forecaster's own chance of this, stated with the estimate: 75%; the middle value does not contradict the limit.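

In this assay compound 2 and compound 3 both stand at a limit and not at a number, so no step between them can be read: the limit of > 20000 nM in this assay, at which 2 of the 3 values shown sit.

The compounds shown leave open whether chloro in place of bromo changes the activity at all.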